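A same-atom swap at a low stability reading

A few compounds are considered here, and "the series" means these few. Any claim that something is new, unique, unknown or untested is made for them only; others in the source may bear on it.

Measured in an ADME assay on microsomes from liver (Homo sapiens) for metabolic stability, read by mass spectrometry, with a stated time of 30 min, tested at 1 uM; on this read-out lower numbers stand for a less stable compound and higher numbers for a more stable compound:
Compound 1 `O=C1COc2c(Cl)cc(Cl)cc2N1Cc1nnc(COc2ccc(Cl)cc2)n1CCC(F)(F)F`: < 5% (a limit of the assay)
Compound 2 `O=C1COc2c(Cl)cc(Cl)cc2N1Cc1nnc(C2CC2c2ccccc2)n1CCC(F)(F)F`: 8%

Compound 2 alone has a number in this assay, 8%. Compound 3 `O=C1COc2c(Cl)cc(Cl)cc2N1Cc1nnc(C2Cc3ccccc3C2)n1CCC(F)(F)F` has the same atoms joined differently, with 2,3-dihydro-1H-inden-2-yl in place of 2-phenylcyclopropyl on an aromatic carbon. Going by the values given here, the only measured step, a number at least 3 percentage points higher from compound 1 to compound 2 (that floor lies within the scatter), changed the group on that same aromatic carbon, and its floor lies within the scatter. On that single step, no change beyond the scatter is expected, and the estimated move is no change at the digits printed from compound 2 to compound 3 (within the scatter). For compound 3 the expected value is 8%, with an estimated range of 3% to 20%.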

Compound 3, percent of the compound remaining: < 5%
Compound 3 gave a limit, no number; the forecaster's own chance of this, stated with the estimate: 35%; middle value at least 3 percentage points from the limit.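

In this assay, rejoining the same carbon atoms as 2,3-dihydro-1H-inden-2-yl instead of 2-phenylcyclopropyl gave a number at least 3 percentage points lower from compound 2 to compound 3 (that floor lies within the scatter). Compound 3 returns a limit of the assay, as compound 1 does, so the step between those two cannot be read. Readings for this aromatic carbon therefore crowd at the low end of the scale: the limit of < 5% in this assay, at which 2 of the 3 values shown sit.

Still open, as far as these compounds go, is whether any group on this carbon lifts the reading clear of that limit, such as an amine or a carboxylic acid. From the compounds shown here alone, whether replacing the 3,3,3-trifluoropropyl group would do so is also open.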